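The source may report more compounds than this note shows. Statements on the series, on what has been measured and on what is new or still open speak of the compounds shown alone.

Measured in an ADME assay on L02 cells (Homo sapiens) for cytotoxicity, read by MTT assay, with a stated time of 24 h; on this read-out lower numbers stand for stronger inhibition and higher numbers for weaker inhibition:
- compound 1 `CN1C/C(=C\c2ccncc2)C(=O)/C(=C/c2ccccc2F)C1` gives 14900 nM
- compound 2 `O=C1/C(=C/c2cccnc2)CN(S(=O)(=O)c2ccccc2)C/C1=C\c1ccccc1F` gives 15300 nM
- compound 3 `O=C1/C(=C/c2ccncc2)CNC/C1=C\c1ccccc1F` gives 14700 nM

Compound 3 sits within the usual scatter of both other compounds, so the three values cannot be ranked. Compound 4 `O=C1/C(=C/c2ccncc2)CN(S(=O)(=O)c2ccccc2)C/C1=C\c1ccccc1F` has phenylsulfonyl in place of hydrogen on an amine nitrogen in a ring. One measured step changes this same nitrogen, a 1.0-fold lower number from compound 1 to compound 3 (0.01 log units; within the scatter), and it stays within the scatter. Compound 2 also carries phenylsulfonyl, and its value lies within the scatter of compound 3, though it differs from compound 4 elsewhere. No step beyond the scatter is therefore expected in this assay, and the estimated change is a 1.0-fold higher number from compound 3 to compound 4 (0.01 log units; within the scatter). Compound 4 is expected at 15000 nM, with an estimated range of 8500 nM to 25000 nM.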

Compound 4, half-maximal inhibitory concentration: 15900 nM
For compound 4 the middle estimate is 1.1-fold (0.03 log units) below the measured one; the range from low to high includes it.
By their numbers in this assay, from the lowest: compounds 3, 1, 2 and 4 (each within the scatter of the next).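

In this assay, phenylsulfonyl on the amine nitrogen in the ring gives a 1.1-fold higher number from compound 3 to compound 4 (0.03 log units; within the scatter) and, in place of methyl, a 1.1-fold higher number from compound 1 to compound 4 (0.03 log units; within the scatter), so hydrogen, methyl and phenylsulfonyl at this nitrogen cannot be told apart. The other new comparison concerns a different place: pyridin-4-yl in place of pyridin-3-yl gives a 1.0-fold higher number from compound 2 to compound 4 (0.02 log units; within the scatter), which shows that this change also stays within the scatter. No measured evidence bears on these results. Still open, from the compounds shown here alone, is whether an acetyl group or a longer alkyl chain on this nitrogen would shift the value beyond the scatter. Going by these compounds, a carboxylic acid on the phenylsulfonyl ring remains equally open.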